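Compound 2 to compound 4: a longer straight chain

This account rests on a few compounds, and the source may have more. Where it says the series, first, only, none or still open, it means among the compounds named here.

Three esters on the shared core have values in an ADME assay on Vero cells (Chlorocebus sabaeus) for cytotoxicity, read by MTT assay; on this read-out higher numbers stand for weaker inhibition and lower numbers for stronger inhibition. Compound 1 `CCC(CC)C(=O)OCC(C)(C)CC1=C(O)C(=O)c2ccccc2C1=O` gives 104000 nM. Compound 2 `CCCC(C)C(=O)OCC(C)(C)CC1=C(O)C(=O)c2ccccc2C1=O` gives 120 nM, the lower of the two numbers available. Compound 3 `CCCCCCCC(=O)OCC(C)(C)CC1=C(O)C(=O)c2ccccc2C1=O` gives > 258000 nM, which is a limit of the assay and not a number.

Compound 4 `CCCCCCCCC(=O)OCC(C)(C)CC1=C(O)C(=O)c2ccccc2C1=O` differs from compound 2 by octyl in place of 1-methylbutyl on a carbonyl carbon, with octyl in place of 1-methylbutyl on a carbonyl carbon. The closest measured change is an at least 2100-fold higher number from compound 2 to compound 3 (3.33 log units; beyond the scatter), a large step that puts heptyl in place of 1-methylbutyl. The step of an 870-fold lower number from compound 1 to compound 2 (2.94 log units; beyond the scatter) is also large, so the low number belongs to a single compound. The step of an at least 2.4-fold higher number from compound 1 to compound 3 (0.39 log units; beyond the scatter) is at least modest. A large rise in this assay is therefore expected, resting mainly on compound 3 at > 258000 nM. The estimated change is a 1700-fold higher number from compound 2 to compound 4 (3.22 log units; beyond the scatter). For compound 4 the expected value is 200000 nM, with an estimated range from 40000 nM to 300000 nM.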

Compound 4, half-maximal inhibitory concentration: 150000 nM
Beside the measured number, compound 4's estimate is 1.3-fold (0.12 log units) above it; the measured number falls inside the stated range.
By their numbers in this assay, from the lowest: compound 2; then compounds 1 and 4 (each within the scatter of the next). At a limit, above all of these: compound 3.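

Compound 4 gives this position its first exact number for an unbranched chain in this assay, and octyl in place of 1-methylbutyl produces a 1300-fold higher number from compound 2 to compound 4 (3.10 log units; beyond the scatter). Octyl in place of pentan-3-yl gives a 1.4-fold higher number from compound 1 to compound 4 (0.16 log units; within the scatter), and among the four esters the low number still belongs to compound 2 alone. Methyl in place of hydrogen on a saturated chain carbon, seven bonds along the chain from a carbonyl carbon, gives an at least 1.7-fold lower number from compound 3 to compound 4 (0.23 log units; that floor lies within the scatter), and that step starts from a limit and not from a number: the limit of > 258000 nM in this assay, at which 1 of the 4 values shown sits.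

What separates 1-methylbutyl from pentan-3-yl remains unexplained by these compounds. Going by these compounds, whether another branched chain such as 1-methylpentyl, or a chain carrying an amine, would share the low number of compound 2 stays open.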